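The source may report more compounds than this note shows. Statements on the series, on what has been measured and on what is new or still open speak of the compounds shown alone.

Working notes on the series. Within the data shown here, in an assay on isolated protein for binding affinity to melanin-concentrating hormone receptor 1 (Homo sapiens) (a higher number here means a weaker inhibitor, a lower number a stronger inhibitor), compound 1 `CN(C(=O)N1CC[C@H](n2cnc3cc(-c4ccc(Cl)cc4)sc3c2=O)C1)[C@H]1CCN(Cc2ccoc2)C1` gives 4 nM and compound 2 `CN(C(=O)N1CC[C@H](n2cnc3cc(-c4ccc(Cl)cc4)sc3c2=O)C1)[C@H]1CCN(CC2CCOC2)C1` gives 4 nM; the step of no change at the digits printed from compound 1 to compound 2 (within the scatter) is the only single-point comparison measured so far. Compound 3 `CN1CC[C@H](N(C)C(=O)N2CC[C@H](n3cnc4cc(-c5ccc(OC(F)(F)F)cc5)sc4c3=O)C2)C1` gives 39 nM in this assay, the highest of the three numbers, with its gaps to compounds 1 and 2 both beyond the scatter.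

Compound 4 `CCOc1ccc(-c2cc3ncn([C@H]4CCN(C(=O)N(C)[C@H]5CCN(C)C5)C4)c(=O)c3s2)c(Cl)c1` differs from compound 3 by 2-chloro-4-ethoxyphenyl in place of 4-(trifluoromethoxy)phenyl on an aromatic carbon. Among the measured compounds shown here, no measured step touches this part of the shared core, so the step from compound 1 to compound 2 does not bear on it, and the direction of change in this assay cannot be inferred. Compound 4 is therefore expected to fall near compound 3, with a wide range: estimated 25 nM (from 5 nM to 120 nM), a step of a 1.6-fold lower number from compound 3 to compound 4 (0.19 log units; within the scatter).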

Compound 4, inhibition constant: 26 nM
Beside the measured number, compound 4's estimate is 1.0-fold (0.02 log units) below it, within the range that was stated.
By their numbers in this assay, from the lowest: compounds 1 and 2 (each within the scatter of the next); then compounds 4 and 3 (each within the scatter of the next).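

Replacing 4-(trifluoromethoxy)phenyl with 2-chloro-4-ethoxyphenyl on this aromatic carbon next to the ring sulfur gives a 1.5-fold lower number from compound 3 to compound 4 (0.18 log units; within the scatter) in this assay. Among these compounds, this is the first measured step at this position, and this exchange of substituted phenyl groups stays within the scatter. No available evidence bears on this result. The compounds shown leave open whether a phenyl ring carrying only the chlorine or only the ethoxy group would read the same. From the compounds shown here alone, how a pyridine ring or a carboxylic acid on the phenyl ring would read at this position also remains open.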